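A few compounds are considered here, and "the series" means these few. Any claim that something is new, unique, unknown or untested is made for them only; others in the source may bear on it.

Two compounds of this series have been run so far in a functional assay on RXF 393 cells (Homo sapiens) for inhibition, read by sulforhodamine B assay, with a stated time of 48 h, tested at 10 uM; a lower number here means a stronger effect, a higher number a weaker effect of the compound at the concentration tested. Compound 1 `COc1cc(Cl)cc(-c2nn(-c3cccc(NC(=O)c4cccc(C(F)(F)F)c4)c3)cc2-c2ccncc2)c1` gives 40.5%. Compound 2 `O=C(Nc1cccc(-n2cc(-c3ccncc3)c(-c3cc(O)cc(Cl)c3)n2)c1)c1cc(C(F)(F)F)cc(C(F)(F)F)c1` gives -10.4%, which is the lowest of the two numbers; its nearest neighbour is compound 1, whose number is higher by a gap beyond the scatter. Going by the values given here, the two compounds differ in more than one place, so no single-change step between them is available, and their values are taken only as they stand.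

The next compound to be measured in this assay is compound 3 `COc1cc(Cl)cc(-c2nn(-c3cccc(NC(=O)c4cc(C(F)(F)F)cc(C(F)(F)F)c4)c3)cc2-c2ccncc2)c1`. Relative to compound 2 the change is methyl in place of hydrogen on an oxygen on an aromatic ring, that is hydroxy to methoxy, 3-chloro-5-hydroxyphenyl to 3-chloro-5-methoxyphenyl. Among the compounds with values here, no measured pair shows this change on its own. Compound 3 also carries the same methoxy group as compound 1, while sharing the bis(trifluoromethyl) benzamide of compound 2, so both measured values bear on it without either fixing it.

The step from compound 2 to compound 3 is expected to be an increase, a number 25.4 percentage points higher from compound 2 to compound 3 (beyond the scatter), beyond the scatter. For compound 3 the expected value in this assay is 15%, with a likely range from -15% to 45%.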

Compound 3, a percentage reported as activity, at one concentration (the size of the read-out at that concentration, not a potency): 67.7%
For compound 3 the middle estimate is 52.7 percentage points below the measured one; measured number outside the range, above it.
By their numbers in this assay, from the lowest: compound 2; then compound 1; then compound 3.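

In this assay the series now has its first single-change readings. Replacing hydroxy with methoxy, 3-chloro-5-hydroxyphenyl to 3-chloro-5-methoxyphenyl, gives a large step, a number 78.1 percentage points higher from compound 2 to compound 3 (beyond the scatter), so with the bis(trifluoromethyl) benzamide in place, the free hydroxy goes with the stronger effect and methylation on this oxygen goes with a much weaker one. With the methoxy group held constant, trifluoromethyl in place of hydrogen on an aromatic carbon gives a modest step in the same direction, a number 27.2 percentage points higher from compound 1 to compound 3 (beyond the scatter), so the added trifluoromethyl goes with a weaker effect on this background and does not recover what the methoxy step loses. Nothing available explains either step.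

The compounds shown leave open whether the added trifluoromethyl would shift the number in the same direction with the hydroxy present, since that step is known only on the methoxy background. They also leave open how specific the result is to hydroxy: an amino group or a carboxylic acid on the same ring carbon, or ethoxy as a longer chain on the oxygen, would show how far the effect of compound 2 extends.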